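The source may report more compounds than this note shows. Statements on the series, on what has been measured and on what is new or still open speak of the compounds shown alone.

Working notes on the series, read in an ADME assay on MRC5 cells (Homo sapiens) for cytotoxicity, read by fluorescence and resazurin assay, with a stated time of 3 days (on this read-out higher numbers stand for lower toxicity in this test and lower numbers for higher toxicity in this test), throughout. Compound 2 `O=C(Nc1cc(-c2ccccn2)n[nH]1)N1CCC(Oc2ccccc2)CC1` reads > 64000 nM as a limit and has no number behind it. Compound 1 `N#Cc1ccc(OC2CCN(C(=O)Nc3cc(-c4ccccn4)n[nH]3)CC2)cc1` reads > 63000 nM and this too is a limit. Those two readings are all that is available, so compound 2 can be placed only at the limit and not ranked against compound 1.

Compound 3 `O=C(Nc1cc(-c2ccccn2)n[nH]1)N1CCC(c2ccccc2)CC1` differs from compound 2 by phenyl in place of phenoxy on a saturated ring carbon. For the measured compounds named here, the one measured step is a step that the two limits leave unreadable from compound 1 to compound 2 and it concerns a different place on the structure. It gives no size to carry over to this change.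

No step beyond the scatter is therefore expected in this assay and no direction can be given. This expectation rests on the limit of compound 2 at > 64000 nM and on nothing firmer. The expected move is an at least 1.0-fold lower number from compound 2 to compound 3 (0.02 log units; that floor lies within the scatter) as an estimate only. For compound 3 the estimated value is 60000 nM with an expected range from 25000 nM to 100000 nM and a report as a limit is the likely outcome.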

Compound 3, half-maximal cytotoxic concentration: > 64000 nM
Compound 3 ended at the assay's limit; the forecaster's own chance of this, stated with the estimate: 75%; middle value at least 1.0-fold (0.02 log units) away from the limit.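

For the compounds shown here, compound 1, compound 2 and compound 3 all read as limits in this assay, and no step among them can be read. The compounds shown leave open how far each lies from its limit, and whether phenyl, phenoxy or 4-cyanophenoxy on the saturated ring carbon makes any difference to this read-out.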